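Notes on the step from compound 3 to compound 4

This account rests on a few compounds, and the source may have more. Where it says the series, first, only, none or still open, it means among the compounds named here.

Measured in a physicochemical assay for solubility, read by spectrophotometry, measured as kinetic solubility, at pH 8, tested at 500 uM; on this read-out higher numbers stand for higher solubility and lower numbers for lower solubility:
- compound 1 `CNS(=O)(=O)c1ccccc1Nc1cc(-c2ccc3ccn(C)c3c2)c2nccnc2c1` gives 2 ug/mL
- compound 2 `CN(Cc1cncnc1)S(=O)(=O)c1ccccc1Nc1cc(-c2ccc3ccn(C)c3c2)c2nccnc2c1` gives 3 ug/mL
- compound 3 `Cn1ccc2ccc(-c3cc(Nc4cnccc4C(=O)NCc4cncnc4)cc4nccnc34)cc21` gives 233 ug/mL

Compound 3 stands highest of the three, and compound 1 and compound 2 both lie far below it, beyond the scatter. The change to compound 4 `CC(=O)N1CCCC(NC(=O)c2ccncc2Nc2cc(-c3ccc4ccn(C)c4c3)c3nccnc3c2)C1` is 1-acetylpiperidin-3-yl in place of (pyrimidin-5-yl)methyl on an amide-type nitrogen, with 1-acetylpiperidin-3-yl entering in place of (pyrimidin-5-yl)methyl on an amide-type nitrogen. Going by the values given here, the only measured step involving (pyrimidin-5-yl)methyl is a 1.5-fold higher number from compound 1 to compound 2 (0.18 log units; within the scatter). It sits on a sulfonamide nitrogen and stays within the scatter, so it offers weak guidance here. Among the compounds with values here, no measured step covers this exchange on an amide-type nitrogen. From the highest value in the series, a moderate downward move in this assay is expected, estimated as a 1.8-fold lower number from compound 3 to compound 4 (0.25 log units; within the scatter). For compound 4 the estimate is 130 ug/mL, with an expected range from 40 ug/mL to 260 ug/mL.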

Compound 4, solubility: 212 ug/mL
For compound 4 the middle estimate is 1.6-fold (0.21 log units) below the measured one; the range from low to high includes it.
By their numbers in this assay, from the lowest: compounds 1 and 2 (each within the scatter of the next); then compounds 4 and 3 (each within the scatter of the next).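

In this assay the exchange of (pyrimidin-5-yl)methyl for 1-acetylpiperidin-3-yl on the amide-type nitrogen gives a 1.1-fold lower number from compound 3 to compound 4 (0.04 log units; within the scatter) and so, at this place, a six-membered aromatic ring and a six-membered non-aromatic ring read alike. The earlier step on a sulfonamide nitrogen covered no such exchange. No evidence at hand accounts for this result. Open, from the compounds shown here alone, is whether a group carrying an amine or a carboxylic acid on this amide-type nitrogen would read the same way in this assay.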